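This account rests on a few compounds, and the source may have more. Where it says the series, first, only, none or still open, it means among the compounds named here.

Working notes on the series. In an assay on HEK293 cells for inhibition of solute carrier family 22 member 12 (Homo sapiens), read by scintillation counting, with stated times of 30 min and 15 min (on this read-out lower numbers stand for stronger inhibition and higher numbers for weaker inhibition), compound 1 `CC(C)(Sc1ccncc1Oc1ccc(C#N)c2ccccc12)C(=O)O` gives 5210 nM, the highest of the two numbers in hand; its nearest neighbour, compound 2 `N#Cc1ccc(Nc2cnccc2SCCCCCC(=O)O)c2ccccc12`, gives 4240 nM in this assay, a gap that lies within the scatter. The unmeasured compound 3 `N#Cc1ccc(Oc2cnccc2SCCCCCC(=O)O)c2ccccc12` differs from compound 1 by a single change, (5-carboxypentyl in place of 1-carboxy-1-methylethyl on a sulfur). For the measured compounds named here, no measured pair isolates this exact change, so the size of the step in this assay is open; a step from compound 1 to compound 3 of about a 1.2-fold lower number from compound 1 to compound 3 (0.06 log units; within the scatter) is expected, that is, none beyond the scatter. Compound 3 is accordingly estimated at 4500 nM, within 2000 nM to 10000 nM.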

Compound 3, half-maximal inhibitory concentration: 4740 nM
For compound 3 the middle estimate is 1.1-fold (0.02 log units) below the measured one; measured number inside the range.
By their numbers in this assay, from the lowest: compounds 2, 3 and 1 (each within the scatter of the next).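

For the compounds shown here, the first isolated reading of 5-carboxypentyl in place of 1-carboxy-1-methylethyl on a sulfur is a 1.1-fold lower number from compound 1 to compound 3 (0.04 log units; within the scatter) in this assay. At this position, a chain of 8 heavy atoms and one of 6 therefore go untold apart by this read-out, provided each carries the carboxylic acid. Nothing available bears on a cause for this result.

Open, from the compounds shown here alone, is whether a chain without the carboxylic acid, such as a plain hexyl, or a tetrazole in its place, would move the number beyond the scatter. Going by these compounds, a shorter carboxyethyl chain on the same sulfur also remains open.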